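The source may report more compounds than this note shows. Statements on the series, on what has been measured and on what is new or still open speak of the compounds shown alone.

The measured compounds in this study are:

compound 1, `Nc1cc(N)c2nc(-c3ccccc3)c(NCc3ccc(Cl)c(Cl)c3)nc2c1`, with 52500 nM
compound 2, `Nc1cc(N)c2nc(-c3ccccc3)c(Sc3ccc(F)cc3)nc2c1`, with < 100000 nM, a limit
compound 3, `COc1cc(CNc2nc3cc(N)cc(N)c3nc2-c2ccccc2)cc(OC)c1OC`, with 8710 nM

In a functional assay on CAKI-1 cells (Homo sapiens) for inhibition, read by sulforhodamine B assay, with a stated time of 48 h (a higher number here means a weaker inhibitor of growth, a lower number a stronger inhibitor of growth), compound 1 gives 52500 nM. Compound 3 gives 8710 nM in this assay. For compound 2 the assay reports only a limit, < 100000 nM, and no number. That is the limit of < 100000 nM in this assay, at which 1 of the 3 values shown sits, so where compound 2 stands among the three on a numerical scale is not known; only the limit is. No two of these compounds differ in a single place, so no measured step can be drawn between them, and compound 1 and compound 3 simply show their two values side by side.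

Compound 4, `Nc1cc(N)c2nc(-c3ccccc3)c(Sc3ccc(Cl)c(Cl)c3)nc2c1`, has not yet been measured. It differs from compound 2 in one place: 3,4-dichlorophenyl in place of 4-fluorophenyl on a sulfur. For the measured compounds named here, with no measured step to lean on, and compound 2 known only as a limit, the step from compound 2 to compound 4 in this assay is expected to be modest, a step that the limit leaves unreadable from compound 2 to compound 4, most likely within or only just beyond the scatter. Compound 4 is therefore estimated at 50000 nM, within a range from 15000 nM to 100000 nM.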

Compound 4, concentration for total growth inhibition: 37200 nM
For compound 4 the middle estimate is 1.3-fold (0.13 log units) above the measured one; the range from low to high includes it.
By their numbers in this assay, from the lowest: compound 3; then compounds 4 and 1 (each within the scatter of the next).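

In this assay, for the compounds shown here, compound 2 is given only as < 100000 nM, which is a limit and not a number, so no step from compound 2 to compound 4 can be read: the limit of < 100000 nM in this assay, at which 1 of the 4 values shown sits. The compounds shown leave open whether 3,4-dichlorophenyl in place of 4-fluorophenyl on a sulfur changes growth inhibition at all, and if so, by how much.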